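Amide substituent change on a cytotoxicity-silent scaffold

The source may hold more compounds than are shown below. What is called first, only, known or untested is meant among the compounds shown, and "the series" means these compounds.

Compound 1 `C=CC1=C(C(=O)NCc2ccc(Cl)cc2)C(c2ccc(OC)c(OC)c2)OC1`: > 100000 nM in a functional assay on A549 cells (Homo sapiens) for cytotoxicity, read by MTT assay, with a stated time of 24 h; on this read-out lower numbers stand for stronger inhibition and higher numbers for weaker inhibition (a limit of the assay)
Compound 2 `C=CC1=C(C(=O)NCc2ccc(Cl)cc2)C(c2ccc(OC)cc2)OC1`: > 100000 nM (a limit)
Compound 3 `C=CC1=C(C(=O)NCCC)C(c2ccc(Cl)c(Cl)c2)OC1`: > 100000 nM (a limit)

Compound 3 shows no measurable effect on this assay within the range tested; its value is a limit of the assay, not a number. The same is true of compound 1 and of compound 2, so all three sit at the limit of > 100000 nM in this assay, at which 3 of the 3 values shown sit. For the measured compounds named here, the only step between two measured compounds, a step that the two limits leave unreadable from compound 1 to compound 2, cannot be read because both ends are limits.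

Compound 4 `C=CC1=C(C(=O)NC(C)(C)C)C(c2ccc(Cl)c(Cl)c2)OC1` differs from compound 3 in one place:

tert-butyl in place of propyl on an amide-type nitrogen

Going by the values given here, no measured step speaks to a change on the amide-type nitrogen, since compound 1 and compound 2 vary on the aromatic ring instead, and every recorded value is a limit. What is known is that each measured compound, whatever its amide side chain, fails to reach a measurable effect in this assay. The step from compound 3 to compound 4 is therefore expected to stay within that pattern, with compound 4 most likely also returning a limit rather than a number: a step that the limit leaves unreadable from compound 3 to compound 4. The expected value for compound 4 is 150000 nM, within 30000 nM to 500000 nM.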

Compound 4, half-maximal inhibitory concentration: > 100000 nM
Compound 4: no number, only a limit; the forecaster's own chance of this, stated with the estimate: 85%; the middle value does not contradict the limit.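

The step from compound 3 to compound 4, tert-butyl in place of propyl on the amide-type nitrogen, cannot be read, since both ends are limits of the assay and not numbers: the limit of > 100000 nM in this assay, at which 4 of the 4 values shown sit.

Whether any change to the amide side chain or the aromatic ring can produce a measurable effect in this assay remains open in the compounds shown.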